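Removing a methoxy group from a benzothiazole-pyrimidine series

The compounds below may be only part of what the source reports. "The series", "measured", "known", "first", "only" and "open" are said of these compounds alone.

Compound 1 `CS(=O)(=O)c1ccc(Nc2ncc(F)c(Nc3nc4ccccc4s3)n2)cc1` and compound 2 `COc1ccc2nc(Nc3nc(Nc4ccc(S(C)(=O)=O)cc4)ncc3F)sc2c1` are close relatives. In a functional assay on MCF7 cells (Homo sapiens) for antiproliferative activity, read by MTT assay, with a stated time of 48 h (on this read-out lower numbers stand for stronger inhibition and higher numbers for weaker inhibition), compound 2 gives 5850 nM, while compound 1 gives 6880 nM, so that a 1.2-fold higher number from compound 2 to compound 1 (0.07 log units; within the scatter). The change made there is hydrogen in place of methoxy on an aromatic carbon. Compound 3 `COc1ccc2nc(Nc3ccnc(Nc4ccc(S(N)(=O)=O)cc4)n3)sc2c1` carries a different core; how its core differs from that of compound 2 is not broken down here. In this assay compound 3 gives 11000 nM. Compound 4 `NS(=O)(=O)c1ccc(Nc2nccc(Nc3nc4ccccc4s3)n2)cc1` arises from compound 3 by the same change, (hydrogen in place of methoxy on an aromatic carbon). Since the earlier step of a 1.2-fold higher number from compound 2 to compound 1 (0.07 log units; within the scatter) stayed within the scatter, the step from compound 3 is expected to be similar, a 1.1-fold higher number from compound 3 to compound 4 (0.06 log units; within the scatter). Compound 4 is therefore estimated at 12500 nM in this assay, with a likely range from 6000 nM to 26000 nM.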

Compound 4, half-maximal inhibitory concentration: 15300 nM
Compound 4: middle estimate off by 1.2-fold (0.09 log units), on the low side; measured number inside the range.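

In this assay, replacing methoxy with hydrogen gives a 1.4-fold higher number from compound 3 to compound 4 (0.14 log units; within the scatter), and this second step agrees with the first: the same change on two cores in this assay, a 1.2-fold higher number (0.07 log units; within the scatter) from compound 2 to compound 1 and a 1.4-fold higher number (0.14 log units; within the scatter) from compound 3 to compound 4, 1.2-fold (0.07 log units) apart, within the scatter of two such steps. On these two cores, then, the change leaves the number within the scatter each time. For the compounds shown here, with only two pairs, this does not show that the same would hold on any other core, nor does it reveal any real contribution from the methoxy group.

The compounds shown leave open whether another group on that aromatic carbon, such as an amine, a chlorine atom or a longer alkoxy chain, would move the number beyond the scatter. They also leave open whether such a group would behave alike on both cores.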